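Aryl swap on the shared core, cell cytotoxicity

The compounds below may be only part of what the source reports. "The series", "measured", "known", "first", "only" and "open" are said of these compounds alone.

Of the compounds shown here, two on the shared core have been measured so far. In a functional assay on RAW264.7 cells (Mus musculus) for cytotoxicity, read by MTT assay, with a stated time of 48 h, tested at 100 uM (a lower number here means a weaker effect, a higher number a stronger effect of the compound at the concentration tested), compound 1 `CS(=O)(=O)c1ccc(Cc2nnc3n2N=C(c2ccc(-c4ccccc4)cc2)CS3)cc1` gives 74.8%, while compound 2 `CS(=O)(=O)c1ccc(Cc2nnc3n2N=C(c2ccc(Cl)cc2Cl)CS3)cc1` gives 31%. Compound 2 thus stands lowest of the two numbers, its nearest neighbour being compound 1 at a gap beyond the scatter. Compound 3 `Cc1ccc(C2=Nn3c(Cc4ccc(S(C)(=O)=O)cc4)nnc3SC2)cc1` is next to be measured and differs from compound 2 by 4-methylphenyl in place of 2,4-dichlorophenyl on a carbon with a double bond to nitrogen. Going by the values given here, no step between measured compounds covers this change, so the expectation rests on the two values alone. The expected step is a number 14 percentage points higher from compound 2 to compound 3 (beyond the scatter), an increase of modest size that may not clear the scatter. Compound 3 is estimated at 45%, with a range from 20% to 75%.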

Compound 3, a percentage reported as activity, at one concentration (the size of the read-out at that concentration, not a potency): 38.5%
Estimate against measurement, compound 3: 6.5 percentage points above; the measured number falls inside the stated range.
By their numbers in this assay, from the lowest: compounds 2 and 3 (each within the scatter of the next); then compound 1.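

In this assay, 4-methylphenyl in place of 2,4-dichlorophenyl on a carbon with a double bond to nitrogen does not separate the two aryl groups (a number 7.5 percentage points higher from compound 2 to compound 3 (within the scatter)). Methyl in place of phenyl on an aromatic carbon of that aryl group has a large effect (a number 36.3 percentage points lower from compound 1 to compound 3 (beyond the scatter)), so among these compounds the high read-out goes with the added phenyl of compound 1. Nothing available explains either step.

From the compounds shown here alone, whether a smaller ring such as pyridine or a polar group such as an amine at that aromatic carbon would retain the read-out of compound 1 remains open.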